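Working notes: from 2-fluorophenyl to 2-bromophenyl

The source may report more compounds than this note shows. Statements on the series, on what has been measured and on what is new or still open speak of the compounds shown alone.

Measured in an ADME assay on BHK cells (Mesocricetus auratus) for cytotoxicity, read by MTT assay, with a stated time of 96 h; on this read-out higher numbers stand for lower toxicity in this test and lower numbers for higher toxicity in this test:
- compound 1 `CCNC(=S)Nc1cccc(C(F)(F)F)c1`: > 100000 nM (a limit of the assay, not a number)
- compound 2 `Fc1ccccc1NC(=S)Nc1cccc(C(F)(F)F)c1`: 54000 nM

Among the compounds with values here, compound 2, at 54000 nM, holds the only true number so far. Compound 3 `FC(F)(F)c1cccc(NC(=S)Nc2ccccc2Br)c1` differs from it as follows: bromo in place of fluoro on an aromatic carbon. Within the data shown here, the one measured step, an at least 1.8-fold lower number from compound 1 to compound 2 (0.26 log units; that floor lies within the scatter), is 2-fluorophenyl in place of ethyl, so it bears only loosely on a change from fluoro to bromo. No step beyond the scatter is therefore expected in this assay. The expected step is a 1.4-fold lower number from compound 2 to compound 3 (0.13 log units; within the scatter). For compound 3 the estimated value is 40000 nM, with an expected range of 15000 nM to 100000 nM.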

Compound 3, half-maximal cytotoxic concentration: 59000 nM
Compound 3: middle estimate off by 1.5-fold (0.17 log units), on the low side, and the stated range covers the measured number.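

In this assay, bromo in place of fluoro on this aromatic carbon gives a 1.1-fold higher number from compound 2 to compound 3 (0.04 log units; within the scatter), so the two halogens are not separated at this position. 2-Bromophenyl in place of ethyl gives an at least 1.6-fold lower number from compound 1 to compound 3 (0.22 log units; that floor lies within the scatter), which, like the 2-fluorophenyl step, is only a floor. Compound 1 carries a limit, not a number, so the full size of both steps from it stays unknown: the limit of > 100000 nM in this assay, at which 1 of the 3 values shown sits.

Open, on these data alone, is whether any group on this aromatic carbon moves the number beyond the scatter. An amine or a carboxylic acid there would test this.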